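The source may hold more compounds than are shown below. What is called first, only, known or untested is meant among the compounds shown, and "the series" means these compounds.

Compound 1 `Fc1cccc(-c2n[nH]cc2N2CCCNCC2)c1`: in an assay on isolated protein for binding affinity to 5-hydroxytryptamine receptor 4 (Homo sapiens) (on this read-out higher numbers stand for weaker inhibition and lower numbers for stronger inhibition), compound 1 gives > 10000 nM, a limit of the assay rather than a number.
Compound 2 `Fc1ccc(-c2n[nH]cc2N2CCCNCC2)cc1`: in this assay compound 2 gives > 10000 nM, again a limit of the assay.
Compound 3 `COc1cccc(-c2n[nH]cc2N2CCCNCC2)c1`: in this assay compound 3 gives > 10000 nM, also a limit.

Compound 1 and compound 2 share the same atoms joined differently; the difference between the two cores is not broken down here. From compound 1 to compound 3 the change is methoxy in place of fluoro on an aromatic carbon, and the step that the two limits leave unreadable from compound 1 to compound 3 stays unreadable because of the limit of > 10000 nM in this assay, at which 3 of the 3 values shown sit. Compound 4 `COc1ccc(-c2n[nH]cc2N2CCCNCC2)cc1` has not been measured; it arises from compound 2 by methoxy in place of fluoro on an aromatic carbon. This is the same kind of change as that from compound 1 to compound 3, not the same: in compound 3 the methoxy sits meta to a large group, in compound 4 para to a large group. The step that the limit leaves unreadable from compound 2 to compound 4 is expected to be small, because compound 2 gives > 10000 nM and the related compound 3 gives > 10000 nM, both limits. Compound 4 is expected to show 20000 nM in this assay, likely reported as a limit, within 8000 nM to 60000 nM.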

Compound 4, inhibition constant: > 10000 nM
Compound 4: a limit, no number; the forecaster's own chance of this, stated with the estimate: 85%; the middle value lies beyond the limit too.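

The step from compound 2 to compound 4 cannot be read in this assay, because both values are limits and not numbers: the limit of > 10000 nM in this assay, at which 4 of the 4 values shown sit.

The compounds shown leave open how far each lies beyond that limit, and whether any change to the shared core would give a readable value in this assay.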